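This account rests on a few compounds, and the source may have more. Where it says the series, first, only, none or still open, it means among the compounds named here.

Compound 1 `CCc1cnc(N2CCC(n3nnc4cc(-c5ccc(S(C)(=O)=O)cc5)ncc43)CC2)nc1` gives 280 nM in a physicochemical assay for solubility, read by HPLC, in phosphate buffer, measured as thermodynamic solubility, with a stated time of 24 h, at pH 6.8; a higher number here means a more soluble compound, a lower number a less soluble compound. Compound 2 `CCc1cnc(N2CCC(n3nnc4cc(-c5ccc(S(C)(=O)=O)cc5F)ncc43)CC2)nc1` reaches only the assay limit of < 120 nM there, so its standing is known just as a bound. That step, an at least 2.3-fold lower number from compound 1 to compound 2 (0.36 log units; beyond the scatter), rests on (the limit of < 120 nM in this assay, at which 1 of the 2 values shown sits). Compound 3 `CCc1cnc(N2CCC(n3nnc4cc(-c5ccc(S(C)(=O)=O)c(F)c5)ncc43)CC2)nc1` differs from compound 2 by 3-fluoro-4-(methylsulfonyl)phenyl in place of 2-fluoro-4-(methylsulfonyl)phenyl on an aromatic carbon. Among the measured compounds shown here, no measured step moves a fluorine between ring positions, so the only guide is the bound on compound 2, and compound 3 is expected to stay near it, with an estimated step of an at least 1.2-fold higher number from compound 2 to compound 3 (0.09 log units; that floor lies within the scatter). Compound 3 is therefore estimated at 150 nM, between 50 nM and 450 nM.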

Compound 3, solubility: < 150 nM
Compound 3: a limit, no number (the forecaster's own chance of this, stated with the estimate: 40%); the middle value sits exactly at the limit.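

Compound 3 gives < 150 nM in this assay, and this is a limit, not a number. With the 3-fluoro-4-(methylsulfonyl)phenyl group, the change of hydrogen to fluoro gives an at least 1.8-fold lower number from compound 1 to compound 3 (0.27 log units; that floor lies within the scatter), so this second fluorine position also ends at a limit, though its floor does not clear the scatter as the floor of the earlier step did. The step between the two fluoro isomers cannot be read, so the two fluorine positions cannot be ranked.

On these data alone, the true values of compound 2 and compound 3 stay open. So does what an amine or a carboxylic acid on this phenyl ring would give.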